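A few compounds are considered here, and "the series" means these few. Any claim that something is new, unique, unknown or untested is made for them only; others in the source may bear on it.

In a functional assay on Bel-7402 cells (Homo sapiens) for cytotoxicity, read by MTT assay, with a stated time of 48 h (on this read-out lower numbers stand for stronger inhibition and higher numbers for weaker inhibition), compound 1 (`COc1cc(-n2c(-c3ccc(Cl)cc3)cn(C(C)=O)c2=O)cc(OC)c1OC`) has the entry "not determined" (no result reported) and offers no comparison. For the measured compounds named here, compound 2 (`COc1ccc(-c2cn(C(C)=O)c(=O)n2-c2cc(OC)c(OC)c(OC)c2)cc1[N+](=O)[O-]`) stands at 35700 nM as the only number. Compound 3 (`COc1ccc(-c2cn(C(C)=O)c(=O)n2-c2cc(OC)c(OC)c(OC)c2)cc1N`) differs from compound 2 in one place (amino in place of nitro on an aromatic carbon): amino in place of nitro on an aromatic carbon, ortho to a methoxy group. Going by the values given here, no measured step calibrates this change, so the expectation is tentative: a lower number, beyond the usual scatter, meaning stronger inhibition. The estimated change is a 7.1-fold lower number from compound 2 to compound 3 (0.85 log units; beyond the scatter) on this reading. Compound 3 is expected at about 5000 nM (estimated range 300 nM to 40000 nM).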

Compound 3, half-maximal inhibitory concentration: 600 nM
Beside the measured number, compound 3's estimate is 8.3-fold (0.92 log units) above it; low and high end bracket the measured number.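

On this assay this aromatic carbon, ortho to a methoxy group and meta to a large group, is the first place in the series shown to respond to a change: a 60-fold lower number from compound 2 to compound 3 (1.77 log units; beyond the scatter) follows from amino in place of nitro. The step is large and shows that the group on this carbon can strongly shift the read-out, though it rests on this single pair. Nothing measured here accounts for the step. Going by these compounds, whether the amino group itself matters, or only the absence of nitro, remains open. A methylamino group, an acetamide or a hydroxyl on this carbon would separate the two.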